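A few compounds are considered here, and "the series" means these few. Any claim that something is new, unique, unknown or untested is made for them only; others in the source may bear on it.

Among the measured compounds shown here, in a functional assay (Homo sapiens) for inhibition, with a stated time of 72 h (a higher number here means a weaker inhibitor, a lower number a stronger inhibitor), compound 1 `COc1cc(C(=O)c2ccc3[nH]ccc3c2)cc(OC)c1OC` gives 111 nM and compound 2 `CCn1ccc2cc(C(=O)c3cc(OC)c(OC)c(OC)c3)ccc21` gives 40 nM, the lower of the two numbers so far. Compound 3 `CCCn1ccc2cc(C(=O)c3cc(OC)c(OC)c(OC)c3)ccc21` differs from compound 2 by methyl in place of hydrogen on a saturated chain carbon, two bonds along the chain from an aromatic nitrogen. For the measured compounds named here, only one measured step bears on this, ethyl in place of hydrogen on an aromatic nitrogen, a modest 2.8-fold lower number from compound 1 to compound 2 (0.44 log units; beyond the scatter). One step gives no firm direction, so a change no larger than that one, possibly within the scatter, is expected. The estimated change is a 1.1-fold higher number from compound 2 to compound 3 (0.05 log units; within the scatter). For compound 3 the expected value is 45 nM, with an estimated range of 18 nM to 110 nM.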

Compound 3, half-maximal inhibitory concentration: 2100 nM
Compound 3: middle estimate off by 47-fold (1.67 log units), on the low side; measured number outside the range, above it.
By their numbers in this assay, from the lowest: compound 2; then compound 1; then compound 3.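

In this assay, ethyl to propyl on the aromatic nitrogen gives a 53-fold higher number from compound 2 to compound 3 (1.72 log units; beyond the scatter) and so more than cancels the gain seen with ethyl. Propyl in place of hydrogen on that nitrogen gives a 19-fold higher number from compound 1 to compound 3 (1.28 log units; beyond the scatter) and leaves compound 3 behind compound 1, so this position tolerates ethyl but not propyl. Nothing available accounts for this sharp reversal.

Open, as far as these compounds go, is whether methyl on the nitrogen matches ethyl. Also open, from the compounds shown here alone, is whether a longer chain such as butyl, or a branched one such as isopropyl, behaves like propyl.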